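This account rests on a few compounds, and the source may have more. Where it says the series, first, only, none or still open, it means among the compounds named here.

Among the compounds with values here, compound 1 `CCCCCNc1nc(N)c2nc(O)n(Cc3ccccc3)c2n1` is the one compound here with a numerical result: in a functional assay (spleen, spleen) for activation, with Mus musculus as the target (on this read-out lower numbers stand for an effect already at smaller amounts and higher numbers for an effect only at larger amounts of compound), compound 1 gives 0.1 uM. Compound 2 `COc1nc2c(N)ncnc2n1Cc1ccccc1` reached no number in this assay; for compound 2 the result is only a limit, > 10 uM. So compound 1 stands alone with a measured concentration, while the second value on record is a limit (the limit of > 10 uM in this assay, at which 1 of the 2 values shown sits).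

Compound 3 `CCCSc1nc(N)c2nc(O)n(Cc3ccccc3)c2n1` has not yet been tested in this assay. It differs from compound 1 in one place: propylsulfanyl in place of pentylamino on an aromatic carbon.

Within the data shown here, no step between two measured compounds is available to guide the expectation, so the estimate rests on the change itself and on the single value of compound 1. The step from compound 1 to compound 3 is expected to be a modest loss, a 5.0-fold higher number from compound 1 to compound 3 (0.70 log units; beyond the scatter), somewhat beyond the usual scatter. For compound 3 the expected value in this assay is therefore 0.5 uM, with a range from 0.1 uM to 3 uM.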

Compound 3, minimum effective concentration: 0.01 uM
Beside the measured number, compound 3's estimate is 50-fold (1.70 log units) above it, outside the stated range (below it).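

Swapping pentylamino for propylsulfanyl on the aromatic carbon between two ring nitrogen atoms gives, in this assay, a 10-fold lower number from compound 1 to compound 3 (1.00 log units; beyond the scatter), so the effect now appears at smaller amounts of compound. This shows that the position accepts a group with 0 hydrogen-bond donors and 4 heavy atoms, and that for this pair the donor of pentylamino is not needed for activity. The values shown give no reason for the gain.

The step changes both the atom attached to the ring and the length of the chain, so the two effects cannot be separated from this pair alone. Propylamino and pentylsulfanyl would each change only one of these, and a longer chain on sulfur, such as hexylsulfanyl, would show how far the trend extends.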